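Hydroxy for cyano on the aryl group of compound 2

A few compounds are considered here, and "the series" means these few. Any claim that something is new, unique, unknown or untested is made for them only; others in the source may bear on it.

Compound 2 `N#Cc1cccc(-c2nc(N)c3nc(-c4ccccc4)sc3n2)c1` gives 594 nM in an assay on CHO cells for displacement of a labelled ligand from adenosine receptor A1 (Homo sapiens), read by scintillation counting, with a stated time of 3 h (a higher number here means a weaker inhibitor, a lower number a stronger inhibitor), the highest of the two numbers seen; the nearest is compound 1 `Nc1nc(-c2ccccc2)nc2sc(-c3ccccc3)nc12` at 148 nM. Compound 3 `Nc1nc(-c2cccc(O)c2)nc2sc(-c3ccccc3)nc12` differs from compound 2 by hydroxy in place of cyano on an aromatic carbon. Going by the values given here, no measured step swaps cyano for hydroxy; the only step known, a 4.0-fold higher number from compound 1 to compound 2 (0.60 log units; beyond the scatter), shows that adding cyano there weakened binding. Since compound 3 lacks that cyano, its number is expected to fall back toward compound 1, a step of a 2.4-fold lower number from compound 2 to compound 3 (0.38 log units; beyond the scatter). Compound 3 is therefore estimated at 250 nM, within 80 nM to 800 nM.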

Compound 3, inhibition constant: 58.5 nM
Compound 3: middle estimate off by 4.3-fold (0.63 log units), on the high side; the measured number lies below the stated range.
By their numbers in this assay, from the lowest: compound 3; then compound 1; then compound 2.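

In this assay, the 3-hydroxyphenyl group does more than undo the loss seen with 3-cyanophenyl (a 10-fold lower number from compound 2 to compound 3 (1.01 log units; beyond the scatter)); it also improves on plain hydrogen (a 2.5-fold lower number from compound 1 to compound 3 (0.40 log units; beyond the scatter)). Cyano at the same aromatic carbon goes the other way (a 4.0-fold higher number from compound 1 to compound 2 (0.60 log units; beyond the scatter)), so the group placed here can shift the number in either direction. No evidence here explains the gap between hydroxy and cyano. As far as these compounds go, whether a methoxy or an amine at this place would also give a lower number than hydrogen stays open. Other places on this ring also remain unexplored in the compounds shown.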